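Replacing the carboxy group in a three-compound series

The compounds below may be only part of what the source reports. "The series", "measured", "known", "first", "only" and "open" are said of these compounds alone.

In a functional assay (a lower number here means a stronger inhibitor, a higher number a weaker inhibitor), compound 1 `CC(C)C[C@@H]1NC(=O)[C@H](CS)NC1=O` gives 100000 nM, compound 2 `CC(C)C[C@@H]1NC(=O)[C@H](CCCCN)NC1=O` gives 160000 nM and compound 3 `CC(C)C[C@@H]1NC(=O)[C@H](CC(=O)O)NC1=O` gives 4000 nM. Compound 3 has the lowest number of the three and is the strongest inhibitor so far. The two steps that introduce its carboxy group are both large and beyond the scatter: a 25-fold lower number from compound 1 to compound 3 (1.40 log units; beyond the scatter) and a 40-fold lower number from compound 2 to compound 3 (1.60 log units; beyond the scatter). By contrast, a 1.6-fold higher number from compound 1 to compound 2 (0.20 log units; within the scatter) lies within the scatter.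

The next compound is compound 4 `CSCC[C@@H]1NC(=O)[C@H](CC(C)C)NC1=O`. Its change from compound 3 is (methylsulfanyl)methyl in place of carboxy on a saturated chain carbon bound to a saturated ring carbon, with (methylsulfanyl)methyl in place of carboxy on a saturated chain carbon bound to a saturated ring carbon. Within the data shown here, no measured step involves this entering group. The closest evidence is the two large steps to compound 3, read in reverse, since compound 1 and compound 2 also lack the carboxy group. That evidence rests on a single carboxy compound, so the expectation is loose.

A large move to a higher number is expected in this assay, and the estimated step is a 15-fold higher number from compound 3 to compound 4 (1.18 log units; beyond the scatter). Compound 4 is estimated at 60000 nM, with an expected range of 15000 nM to 200000 nM.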

Compound 4, half-maximal inhibitory concentration: 800000 nM
The estimate for compound 4 lay 13-fold (1.12 log units) below the measured number; the measured number lies above the stated range.
By their numbers in this assay, from the lowest: compound 3; then compounds 1 and 2 (each within the scatter of the next); then compound 4.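

In this assay, among these compounds, the carboxy group gives way to (methylsulfanyl)methyl with a 200-fold higher number from compound 3 to compound 4 (2.30 log units; beyond the scatter), the largest step so far, and compound 4 now has the highest number of the four, with its steps to all the others beyond the scatter. Removing the carboxy group is therefore not a single outcome at this position, as the carboxy-free compounds also separate from one another: an 8.0-fold higher number from compound 1 to compound 4 (0.90 log units; beyond the scatter) and a 5.0-fold higher number from compound 2 to compound 4 (0.70 log units; beyond the scatter) are both modest but beyond the scatter, so the identity of the replacing group still matters once the carboxy group has gone. Nothing available explains the size of these steps.

Among the compounds shown here, compound 3 remains the only carboxy compound here, so it is open whether the low number needs the carboxy group itself or would survive with a primary carboxamide or a methyl ester in its place. Chain length is equally open, and a 2-carboxyethyl group in place of the carboxymethyl group would test how closely the low number depends on where the acid sits.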